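The compounds below may be only part of what the source reports. "The series", "measured", "known", "first", "only" and "open" are said of these compounds alone.

Compounds measured so far:
compound 1 `COc1cc(CNC(=O)/C=C/c2ccc(O)cc2)ccc1OCc1nc(C)c(C)nc1C` — 3740 nM
compound 2 `COc1cc(CNC(=O)/C=C/c2ccc(OCc3nc(C)c(C)nc3C)cc2)ccc1OCc1nc(C)c(C)nc1C` — 7770 nM

Going by the values given here, in a functional assay on SH-SY5Y cells (Homo sapiens) for cytotoxicity, read by MTT assay, with stated times of 24 h and 4 h (on this read-out lower numbers stand for an effect already at smaller amounts and higher numbers for an effect only at larger amounts of compound), compound 2 gives the higher of the two numbers, with compound 1 as its only neighbour, a 2.1-fold higher number from compound 1 to compound 2 (0.32 log units; beyond the scatter). Compound 3 `COc1cc(/C=C/C(=O)NCc2ccc(OCc3nc(C)c(C)nc3C)c(OC)c2)ccc1OCc1nc(C)c(C)nc1C` carries one further change on the shared core: methoxy in place of hydrogen on an aromatic carbon, placed on an aromatic carbon of a six-membered aromatic ring of carbon only, ortho to a (3,5,6-trimethylpyrazin-2-yl)methoxy group and meta to a large group. Among the compounds with values here, no measured step involves a methoxy group; the only step available, from compound 1 to compound 2, concerns a different group on a different ring and was modest. Compound 3 is therefore expected to sit close to compound 2 in this assay, a 1.2-fold higher number from compound 2 to compound 3 (0.06 log units; within the scatter), with no firm direction, and its value is estimated at 9000 nM (range 4000 nM to 20000 nM).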

Compound 3, half-maximal effective concentration: 11100 nM
The estimate for compound 3 lay 1.2-fold (0.09 log units) below the measured number, within the range that was stated.
By their numbers in this assay, from the lowest: compound 1; then compounds 2 and 3 (each within the scatter of the next).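

In this assay, methoxy in place of hydrogen on an aromatic carbon, ortho to a (3,5,6-trimethylpyrazin-2-yl)methoxy group and meta to a large group, gives a 1.4-fold higher number from compound 2 to compound 3 (0.15 log units; within the scatter), so the numbers of these two compounds cannot be told apart. Going by these compounds alone, this is the first reading at this position, and the step stays within the scatter, whereas the earlier step at a different place, a 2.1-fold higher number from compound 1 to compound 2 (0.32 log units; beyond the scatter), lies beyond it. Nothing available explains this result.

The compounds shown leave open whether an amine or a carboxylic acid at this position would also stay within the scatter of compound 2. They also leave open whether methoxy at this position would read the same on the core of compound 1.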